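A few compounds are considered here, and "the series" means these few. Any claim that something is new, unique, unknown or untested is made for them only; others in the source may bear on it.

Working notes on the series. Compound 1 `C/C(=N\NC(=O)c1cccc(S(=O)(=O)N2CCOCC2)c1)c1cccc(N)c1` and compound 2 `C/C(=N\NC(=O)c1cccc(S(=O)(=O)N2CCOCC2)c1)c1cccc(O)c1` differ by hydroxy in place of amino on an aromatic carbon; compound 3 `C/C(=N\NC(=O)c1cccc(S(=O)(=O)N2CCOCC2)c1)c1ccc(O)cc1` has not yet been measured. In a functional assay on PC-3 cells (Homo sapiens) for antiproliferative activity, read by MTT assay, with a stated time of 72 h (a higher number here means a weaker inhibitor, a lower number a stronger inhibitor), compound 1 gives > 100000 nM, which is a limit of the assay and not a number. In this assay compound 2 gives > 100000 nM, again a limit rather than a number. The step that the two limits leave unreadable from compound 1 to compound 2 cannot be read, both values sitting at the limit (the limit of > 100000 nM in this assay, at which 2 of the 2 values shown sit). Compound 2 therefore stands only at a limit in this assay, with no numeric position on the scale. The change to compound 3 is 4-hydroxyphenyl in place of 3-hydroxyphenyl on a carbon with a double bond to nitrogen. Within the data shown here, no measured step bears on this move: the only step recorded, a step that the two limits leave unreadable from compound 1 to compound 2, is unreadable and concerns a different change. The expectation for compound 3 in this assay is that the step that the limit leaves unreadable from compound 2 to compound 3 amounts to nothing readable beyond the scatter, the value most likely remaining at the limit. Compound 3 is estimated at 150000 nM, with a range from 30000 nM to 1000000 nM, and a high chance that only a limit is reported.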

Compound 3, half-maximal inhibitory concentration: 36200 nM
For compound 3 the middle estimate is 4.1-fold (0.62 log units) above the measured one; measured number inside the range.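

Setting 4-hydroxyphenyl in place of 3-hydroxyphenyl on the carbon with a double bond to nitrogen gives, in this assay, an at least 2.7-fold lower number from compound 2 to compound 3 (0.44 log units; beyond the scatter), the first readable step in the series; the two compounds have the same atoms, joined differently, so the way the hydroxy-bearing group is joined matters here and not only the atoms it contains. Replacing 3-aminophenyl at the same place with 4-hydroxyphenyl gives an at least 2.7-fold lower number from compound 1 to compound 3 (0.44 log units; beyond the scatter), so compound 3 also separates from the amino compound, which the earlier pair could not do. The step from compound 1 to compound 2 remains unreadable, and the two readable steps give only lower bounds on their size, because compounds 1 and 2 both sit at a limit: the limit of > 100000 nM in this assay, at which 2 of the 3 values shown sit.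

The compounds shown leave open whether the hydroxy group itself is what counts in 4-hydroxyphenyl, a question that a methoxy group, an amine or a carboxylic acid in its place would address. They also leave open how a plain phenyl group on the same carbon would compare with compound 3.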